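The compounds below may be only part of what the source reports. "The series", "measured", "known", "first", "only" and "open" are said of these compounds alone.

Three compounds built on one shared core have been run in a functional assay on A549 cells (Homo sapiens), read by MTT assay, with a stated time of 72 h; on this read-out higher numbers stand for weaker inhibition and lower numbers for stronger inhibition. Compound 1 `Cc1ncnc2c1c(-c1cccs1)cn2[C@@H]1O[C@H](CO)[C@@H](O)[C@H]1O` carries a thiophen-2-yl group, and in this assay compound 1 gives only a limit, > 20000 nM. Compound 2 `CN(C)c1ncnc2c1c(-c1cc3ccccc3o1)cn2[C@@H]1O[C@H](CO)[C@@H](O)[C@H]1O` carries a 1-benzofuran-2-yl group, and in this assay compound 2 likewise gives only a limit, > 20000 nM. Compound 3 `CN(C)c1ncnc2c1c(-c1ccoc1)cn2[C@@H]1O[C@H](CO)[C@@H](O)[C@H]1O` carries a furan-3-yl group, and in this assay compound 3 also stops at a limit, > 20000 nM. Among the compounds with values here, the one step among them, a step that the two limits leave unreadable from compound 2 to compound 3, runs between two limits and cannot be read. The whole of the evidence is the limit of > 20000 nM in this assay, at which 3 of the 3 values shown sit.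

Compound 4 `CN(C)c1ncnc2c1c(-c1cccs1)cn2[C@@H]1O[C@H](CO)[C@@H](O)[C@H]1O` has not yet been measured. It differs from compound 3 as follows: thiophen-2-yl in place of furan-3-yl on an aromatic carbon. Compound 1 already carries the thiophen-2-yl group that enters here. No shift beyond the scatter is expected, because compound 1 gives > 20000 nM in this assay. The step expected from compound 3 to compound 4 is a step that the limit leaves unreadable from compound 3 to compound 4. Compound 4 is therefore estimated at 30000 nM, within 10000 nM to 100000 nM.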

Compound 4, half-maximal inhibitory concentration: > 20000 nM
Compound 4: only a limit was reported; the forecaster's own chance of this, stated with the estimate: 85%; the middle value lies beyond the limit too.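

Compound 4, like compound 1, compound 2 and compound 3, gives only a limit in this assay, so none of the steps to compound 4 can be read. The compounds shown leave open how any of these groups would rank once a value falls inside the limit: the limit of > 20000 nM in this assay, at which 4 of the 4 values shown sit.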